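Chloro in Place of Fluoro: Solubility Outlook for Compound 4

A few compounds are considered here, and "the series" means these few. Any claim that something is new, unique, unknown or untested is made for them only; others in the source may bear on it.

Compound 1 `Cc1cc(NC(=O)Nc2cccc(F)c2)c2ccccc2n1`: 100 nM
Compound 2 `Cc1cc(NC(=O)Nc2cc(F)cc(F)c2)c2ccccc2n1`: 300 nM
Compound 3 `Cc1cc(NC(=O)Nc2cc(F)ccc2F)c2ccccc2n1`: 500 nM

In a physicochemical assay for solubility, at pH 7.4 (a higher number here means a more soluble compound, a lower number a less soluble compound), compound 1 stands lowest of the three measured compounds. The two measured steps, a 3.0-fold higher number from compound 1 to compound 2 (0.48 log units; beyond the scatter) and a 5.0-fold higher number from compound 1 to compound 3 (0.70 log units; beyond the scatter), are both modest rises, and each is fluoro in place of hydrogen on an aromatic carbon. Compound 4 `Cc1cc(NC(=O)Nc2cccc(Cl)c2)c2ccccc2n1` differs from compound 1 as follows: chloro in place of fluoro on an aromatic carbon. Among the measured compounds shown here, no measured step swaps one halogen for another, so neither bears directly on this change. With nothing to point either way, the step is expected to stay within the scatter, no change at the digits printed from compound 1 to compound 4 (within the scatter). Compound 4 is therefore estimated at 100 nM, within a range of 40 nM to 250 nM.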

Compound 4, solubility: 800 nM
Estimate against measurement, compound 4: 8.0-fold (0.90 log units) below; measured number above the stated range.
By their numbers in this assay, from the lowest: compound 1; then compounds 2, 3 and 4 (each within the scatter of the next, the first and the last beyond it).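

In this assay, the change from 3-fluorophenyl to 3-chlorophenyl gives an 8.0-fold higher number from compound 1 to compound 4 (0.90 log units; beyond the scatter). One halogen exchanged for another on this aromatic carbon, meta to a large group, thus moves the number beyond the scatter, with no change in the counted hydrogen-bond donors or acceptors. The earlier steps shown here, each fluoro in place of hydrogen, did not show this. Going by these compounds, how a bromo, a methoxy or an amine on the same carbon would read in this assay remains open. Nothing available accounts for the size of this step.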